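A few compounds are considered here, and "the series" means these few. Any claim that something is new, unique, unknown or untested is made for them only; others in the source may bear on it.

Measured compounds:
compound 1 `CCOC(=O)c1ccc(CO/N=C/c2c(C)nn(C)c2Oc2ccc(Cl)cc2)cc1` with 20.9%
compound 2 `Cc1nn(C)c(Oc2ccccc2)c1/C=N/OCc1ccc(C(F)(F)F)cc1` with 11%
compound 3 `Cc1nn(C)c(Oc2ccc(Cl)cc2)c1/C=N/OCc1ccc(C(F)(F)F)cc1` with 27.6%

In a functional assay on MKN-45 cells (Homo sapiens) for antiproliferative activity, tested at 1 uM (on this read-out lower numbers stand for less inhibition and higher numbers for more inhibition at the one concentration tested (going by the name of the read-out)), compound 2 gives 11%, which puts it at the low end of the three numbers. Compound 1 lies within the scatter of it, so the two cannot be ordered; only compound 3 is separated from it, with a number 16.6 percentage points higher from compound 2 to compound 3 (beyond the scatter), a step in which chloro replaces hydrogen on the phenoxy ring of the shared core. Compound 4 `Cc1nn(C)c(Oc2ccccc2)c1/C=N/OCc1ccc([N+](=O)[O-])cc1` differs from compound 2 elsewhere: nitro in place of trifluoromethyl on an aromatic carbon. Within the data shown here, the only measured step that touches the same position is the one from compound 1 to compound 3, where trifluoromethyl replaced ethoxycarbonyl and gave a number 6.7 percentage points higher from compound 1 to compound 3 (within the scatter). That single step suggests that exchanging the group at this position moves the read-out little, though it is one pair only and involves different groups from nitro. Compound 4 is therefore expected to stay close to compound 2 in this assay, with a number 3 percentage points higher from compound 2 to compound 4 (within the scatter) as the estimated step, a change that should not exceed the scatter. On this basis compound 4 is estimated at 14%, within a range from 2% to 30%.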

Compound 4, a percentage reported as inhibition, at one concentration (the size of the read-out at that concentration, not a potency): 18.3%
For compound 4 the middle estimate is 4.3 percentage points below the measured one, and the stated range covers the measured number.
By their numbers in this assay, from the lowest: compounds 2, 4, 1 and 3 (each within the scatter of the next, the first and the last beyond it).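

Nitro in place of trifluoromethyl, para to a large group, gives a number 7.3 percentage points higher from compound 2 to compound 4 (within the scatter) in this assay, so this position has now been exchanged on the shared core without the chloro as well as on the chloro-bearing core, where the step was a number 6.7 percentage points higher from compound 1 to compound 3 (within the scatter). Neither of these two exchanges leaves the scatter, even though this one swaps a group with 0 hydrogen-bond acceptors for one with 2, so the count of acceptors at this place does not by itself separate compound 2 from compound 4 here. Nothing measured on these compounds accounts for the size of the step, and it rests on one concentration and one cell line.

The compounds shown leave open whether the step seen with chloro in place of hydrogen, a number 16.6 percentage points higher from compound 2 to compound 3 (beyond the scatter), carries over when nitro occupies this position, since that step is known only with trifluoromethyl. They also leave open how an amine, a carboxylic acid or a longer alkyl chain at this place would read, and whether any group here would move the number beyond the scatter.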